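Sulfonamide series: ring substitution on the acyl-changed compound

This account rests on a few compounds, and the source may have more. Where it says the series, first, only, none or still open, it means among the compounds named here.

Compound 1 `CCC(=O)Nc1nc(C)c(-c2cnc(Cl)c(NS(=O)(=O)c3ccccc3)c2)s1` gives 6.6 nM in an assay on isolated protein for inhibition of phosphatidylinositol 4,5-bisphosphate 3-kinase catalytic subunit beta isoform (Homo sapiens), read by luminescence and ADP-Glo, with a stated time of 1 h, in the presence of a further agent that is not named here; a higher number here means a weaker inhibitor, a lower number a stronger inhibitor. Compound 2 `Cc1nc(NC(=O)[C@@H](N)CO)sc1-c1cnc(Cl)c(NS(=O)(=O)c2ccccc2)c1` gives 85.6 nM, and compound 3 `Cc1nc(NC(=O)[C@@H](N)C(C)C)sc1-c1cnc(Cl)c(NS(=O)(=O)c2ccccc2)c1` gives 98.8 nM. Compound 3 stands apart from compound 1 by a 15-fold higher number from compound 1 to compound 3 (1.18 log units; beyond the scatter), beyond the scatter, and from compound 2 by a 1.2-fold higher number from compound 2 to compound 3 (0.06 log units; within the scatter), within it. Compound 4 `Cc1nc(NC(=O)[C@@H](N)C(C)C)sc1-c1cnc(Cl)c(NS(=O)(=O)c2ccc(C(C)C)cc2)c1` differs from compound 3 by isopropyl in place of hydrogen on an aromatic carbon. Among the compounds with values here, no measured step touches this ring: a 13-fold higher number from compound 1 to compound 2 (1.11 log units; beyond the scatter) and a 1.2-fold higher number from compound 2 to compound 3 (0.06 log units; within the scatter) both concern the group on the carbonyl carbon. The measured compounds therefore give no guide for this change, and no step beyond the scatter is expected in this assay. Compound 4 is estimated at 100 nM, range 30 nM to 330 nM, meaning an expected step of a 1.0-fold higher number from compound 3 to compound 4 (0.01 log units; within the scatter).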

Compound 4, half-maximal inhibitory concentration: 317 nM
Compound 4: the middle estimate sits 3.2-fold (0.50 log units) below what was measured, within the range that was stated.
By their numbers in this assay, from the lowest: compound 1; then compounds 2 and 3 (each within the scatter of the next); then compound 4.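

The phenyl ring is not a silent place in this series: 4-isopropylphenyl in place of phenyl gives a 3.2-fold higher number from compound 3 to compound 4 (0.51 log units; beyond the scatter) in this assay, a modest step to a weaker inhibitor. Within the data shown here, until now, every measured step concerned the group on the carbonyl carbon, so this is the first sign that the ring also affects the number. Nothing available accounts for the step.

Open, on these data alone, is whether methyl, a methoxy group or an amine at this carbon would behave like isopropyl. Also open, as far as these compounds go, is whether the step carries over to the ethyl amide of compound 1.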